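Amide-to-urea step on the pyrazole series, A498 growth

This account rests on a few compounds, and the source may have more. Where it says the series, first, only, none or still open, it means among the compounds named here.

Measured so far:
compound 1 `COc1cc(-c2nn(-c3cccc(NC(=O)c4ccc(Cl)c(C(F)(F)F)c4)c3)cc2-c2ccncc2)ccc1Cl` — 2700 nM
compound 2 `O=C(Nc1cccc(-n2cc(-c3ccncc3)c(-c3ccc(Cl)c(O)c3)n2)c1)Nc1cc(C(F)(F)F)cc(C(F)(F)F)c1` — 792 nM
compound 3 `O=C(Nc1cccc(-n2cc(-c3ccncc3)c(-c3ccc(Cl)c(O)c3)n2)c1)Nc1ccc(Cl)c(C(F)(F)F)c1` — 1400 nM

In a functional assay on A498 cells (Homo sapiens) for inhibition, read by sulforhodamine B assay, with a stated time of 48 h (a higher number here means a weaker inhibitor of growth, a lower number a stronger inhibitor of growth), compound 1 gives 2700 nM, the highest of the three numbers. Compound 3 gives 1400 nM, which lies within the scatter of compound 1, so no order between the two can be read. Compound 2 gives 792 nM, a gap to compound 1 that lies beyond the scatter. Compounds 2 and 3 differ from compound 1 in more than one place, so their values are not single steps and only show the range the series has covered so far.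

Compound 4 `COc1cc(-c2nn(-c3cccc(NC(=O)Nc4ccc(Cl)c(Cl)c4)c3)cc2-c2ccncc2)ccc1Cl` is not yet measured. It differs from compound 1 in one place: (3,4-dichlorophenyl)amino in place of 4-chloro-3-(trifluoromethyl)phenyl on a carbonyl carbon

Among the compounds with values here, no single step of this kind stands among the measured compounds. Compounds 2 and 3 both carry an amino-linked aryl on the carbonyl carbon and both sit at lower numbers than compound 1, which gives a weak lean toward a lower number for compound 4, but the change to the ring is also new and the lean is slight. The expected step of a 1.6-fold lower number from compound 1 to compound 4 (0.20 log units; within the scatter) in this assay is a small decrease, likely within the scatter. Compound 4 is estimated at 1700 nM, with a range from 600 nM to 5000 nM.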

Compound 4, concentration for 50% growth inhibition: 1140 nM
Estimate against measurement, compound 4: 1.5-fold (0.17 log units) above; measured number inside the range.
By their numbers in this assay, from the lowest: compounds 2, 4, 3 and 1 (each within the scatter of the next, the first and the last beyond it).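

In this assay, the exchange of 4-chloro-3-(trifluoromethyl)phenyl for (3,4-dichlorophenyl)amino on the carbonyl carbon gives the series its first single step, a 2.4-fold lower number from compound 1 to compound 4 (0.37 log units; beyond the scatter), so the number at this position does respond, though only modestly. The step joins two changes, since the entering group brings an amino link with a hydrogen-bond donor and also a different set of ring substituents, and these data do not separate the two. Nothing measured here accounts for the drop in the number.

As far as these compounds go, it remains open how much of the step belongs to the amino link alone, a question that a urea carrying the unchanged 4-chloro-3-(trifluoromethyl)phenyl ring on the shared core would address directly. From the compounds shown here alone, the reach of this position beyond aryl groups is also open, for instance with a piperidine or a longer alkyl chain on the same carbonyl carbon, or with a methylamino link in place of the amino link.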